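The compounds below may be only part of what the source reports. "The series", "measured", "known", "first", "only" and "open" are said of these compounds alone.

Measured so far in an ADME assay on A549 cells (Homo sapiens) for cytotoxicity, read by resazurin assay, with a stated time of 48 h; on this read-out lower numbers stand for higher toxicity in this test and higher numbers for lower toxicity in this test:
- compound 1 `O=C(Nc1ccc(NCc2ccc(F)cc2)cc1Cl)c1cc(Cl)ccc1O`: 54400 nM
- compound 2 `CN(C)c1ccc(CNc2ccc(NC(=O)c3cc(Cl)ccc3O)c(Cl)c2)cc1`: 24500 nM
- compound 3 `O=C(Nc1ccc(NCc2ccc3cn[nH]c3c2)cc1Cl)c1cc(Cl)ccc1O`: 45300 nM

Compound 1 stands at the highest of the three numbers, that is the least toxic read in this set. Its nearest neighbour is compound 3, with a 1.2-fold lower number from compound 1 to compound 3 (0.08 log units; within the scatter), and its furthest is compound 2, with a 2.2-fold lower number from compound 1 to compound 2 (0.35 log units; beyond the scatter). Between compound 2 and compound 3 the gap is a 1.8-fold higher number from compound 2 to compound 3 (0.27 log units; within the scatter). Going by the values given here, all three numbers sit in a narrow band, and only the step to compound 2 clears the scatter.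

The next compound is compound 4 `CC(CCO)Nc1ccc(NC(=O)c2cc(Cl)ccc2O)c(Cl)c1`. Relative to compound 1 the change is 3-hydroxy-1-methylpropyl in place of 4-fluorobenzyl on a nitrogen on an aromatic ring.

Both measured steps from compound 1 alter only the aromatic part of the benzyl group; none exchanges the whole 4-fluorobenzyl for a chain without a ring. The steps therefore bear on compound 4 only loosely: they show that changes at this position have so far moved the number little, with the dimethylamino step as the one modest exception. Among the compounds with values here, no measured step points towards higher toxicity for a smaller, ring-free group.

For compound 4 the expectation is a step of a 1.3-fold higher number from compound 1 to compound 4 (0.11 log units; within the scatter), that is no change beyond the scatter or a slight rise, and the estimate is 70000 nM, within 30000 nM to 160000 nM.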

Compound 4, half-maximal cytotoxic concentration: 200000 nM
Beside the measured number, compound 4's estimate is 2.9-fold (0.46 log units) below it; measured number outside the range, above it.
By their numbers in this assay, from the lowest: compounds 2, 3 and 1 (each within the scatter of the next, the first and the last beyond it); then compound 4.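

In this assay, going by these compounds alone, the exchange of the whole 4-fluorobenzyl for 3-hydroxy-1-methylpropyl on the nitrogen gives a 3.7-fold higher number from compound 1 to compound 4 (0.57 log units; beyond the scatter) and is the first step at this position to raise the number beyond the scatter; the earlier changes, which all kept an aromatic ring in the group, left the number within the scatter or lowered it. The position therefore does respond in this test, and among the four compounds the highest number belongs to compound 4 with its ring-free group, at 200000 nM in this assay. Nothing available here accounts for the rise.

This single step loses the aromatic ring and the fluorine, reduces the group from 8 heavy atoms to 5, and brings in a hydroxyl, so the compounds shown leave open which of these changes goes with the higher number. Also open, going by these compounds, is whether a plain butyl chain without the hydroxyl, or a cyclohexylmethyl group that keeps a non-aromatic ring, would give a number closer to compound 1 or to compound 4 on the same nitrogen.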